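Benzyl for methyl on selenium: expected effect on cytotoxicity

The source may hold more compounds than are shown below. What is called first, only, known or untested is meant among the compounds shown, and "the series" means these compounds.

Compound 1 `CS/C(=N\C(=O)c1sccc1Cl)NC(=O)c1sccc1Cl` and compound 2 `C[Se]/C(=N\C(=O)c1cccs1)NC(=O)c1cccs1` are the measured members of this set. In a functional assay on MCF7 cells (Homo sapiens) for cytotoxicity, read by MTT assay, with a stated time of 72 h (on this read-out higher numbers stand for lower toxicity in this test and lower numbers for higher toxicity in this test), compound 1 gives > 100000 nM, which is a limit of the assay and not a number. In this assay compound 2 gives > 100000 nM, again a limit of the assay rather than a number. Among the compounds with values here, compound 2 therefore stands at the limit of > 100000 nM in this assay, at which 2 of the 2 values shown sit, and no measured step between the two compounds exists. Compound 3 `O=C(/N=C(/NC(=O)c1cccs1)[Se]Cc1ccccc1)c1cccs1` is not yet measured. It differs from compound 2 by phenyl in place of hydrogen on a saturated chain carbon bound to a selenium atom. Within the data shown here, with no measured step to guide it, this change is expected to produce no step beyond the scatter in this assay, in either direction. Compound 3 is therefore expected to give roughly 150000 nM in this assay, within a range of 40000 nM to 600000 nM. The step that the limit leaves unreadable from compound 2 to compound 3 is thus estimated as no more than scatter, with a limit again the most likely report.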

Compound 3, concentration lethal to 50% of the cells: > 100000 nM
Compound 3: no number, only a limit; the forecaster's own chance of this, stated with the estimate: 75%; the middle value is on the limit's open side.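

No step can be read from compound 2 to compound 3 in this assay, since each compound gives only a limit of the assay and not a number. The compounds shown leave open whether methyl to benzyl changes cytotoxicity at all in this assay.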